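Amine-side aryl exchange in a hydrolase inhibitor series

The compounds below may be only part of what the source reports. "The series", "measured", "known", "first", "only" and "open" are said of these compounds alone.

Measured so far in an assay on isolated protein for inhibition of Fatty-acid amide hydrolase 1 (Homo sapiens); a higher number here means a weaker inhibitor, a lower number a stronger inhibitor:
compound 1, `O=C(CCCC1CCN(C(=O)CCc2ccccc2)CC1)c1ncco1`, gives 22 nM
compound 2, `O=C(CCCC1CCN(C(=O)CC2CCCCC2)CC1)c1ncco1`, gives 100 nM
compound 3, `Cc1cccc(CN2CCC(CCCC(=O)c3ncco3)CC2)c1`, gives 90 nM

Compound 3 sits second highest of the three numbers in this assay. Its nearest neighbour is compound 2, within the scatter of it, so no order between the two can be read. Compound 1 lies furthest from it, beyond the scatter, with the lower number.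

Compound 4, `O=C(CCCC1CCN(Cc2ccc(Br)cc2)CC1)c1ncco1`, is not yet measured. It differs from compound 3 by 4-bromophenyl in place of 3-methylphenyl on a saturated chain carbon bound to an amine nitrogen in a ring.

Going by the values given here, the only measured step, a 4.5-fold higher number from compound 1 to compound 2 (0.66 log units; beyond the scatter), concerns the saturated chain carbon bound to a carbonyl carbon, on the other side of the shared core. Among the compounds with values here, no measured step touches the position changed here, so nothing in the three numbers speaks directly to this exchange. The expectation is therefore a step of no change at the digits printed from compound 3 to compound 4 (within the scatter), that is, no change beyond the scatter, with compound 3 as anchor. Compound 4 is expected to give about 90 nM in this assay, within a range of 30 nM to 270 nM.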

Compound 4, half-maximal inhibitory concentration: 45 nM
Compound 4: middle estimate off by 2.0-fold (0.30 log units), on the high side; the measured number falls inside the stated range.
By their numbers in this assay, from the lowest: compound 1; then compounds 4, 3 and 2 (each within the scatter of the next, the first and the last beyond it).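

Going by these compounds alone, this is the only step read at the saturated chain carbon bound to an amine nitrogen in a ring, and in this assay it is a 2.0-fold lower number from compound 3 to compound 4 (0.30 log units; within the scatter). The exchange of 3-methylbenzyl for 4-bromobenzyl therefore leaves no order to read between the two compounds, although both the substituent and its printed ring number differ. Nothing available bears on the reason for this outcome.

The pair does not separate the substituent from its ring number; 4-methylbenzyl and 3-bromobenzyl would do so. Going by these compounds, it also remains open whether a group further from these two at the same place, such as an unsubstituted benzyl, a pyridylmethyl or a benzyl carrying a carboxylic acid, would give a step beyond the scatter.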